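The source may report more compounds than this note shows. Statements on the series, on what has been measured and on what is new or still open speak of the compounds shown alone.

In a functional assay on ECa-109 cells for antiproliferative activity against ECa-109 cell line (Homo sapiens), read by MTT assay, with a stated time of 48 h (a lower number here means a stronger inhibitor, a higher number a weaker inhibitor), compound 2 (`COc1ccc(CN(C(=O)CSc2nc3ccc(OC)cc3s2)c2cc(OC)c(OC)c(OC)c2)cc1`) gives > 80000 nM as its reading, which is a limit of the assay and not a number. Compound 1 (`COc1ccc(CN(C(=O)CSC2=CN=NC2C)c2cc(OC)c(OC)c(OC)c2)cc1`) gives > 80000 nM as its reading, and this too is only a limit. Compound 2 thus stands at the limit of > 80000 nM in this assay, at which 2 of the 3 values shown sit, and has no number of its own. Compound 3 (`COc1ccc(CN(C(=O)CCCCSc2nc3ccccc3o2)c2cc(OC)c(OC)c(OC)c2)cc1`) gives 7650 nM as a true number. Among the measured compounds shown here, no measured step connects compound 3 to compound 1 or compound 2.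

Compound 4 (`COc1ccc(CN(C(=O)CSc2nncs2)c2cc(OC)c(OC)c(OC)c2)cc1`) carries 1,3,4-thiadiazol-2-yl in place of 6-methoxy-1,3-benzothiazol-2-yl on a sulfur. For the measured compounds named here, only one measured step bears on that sulfur (a step that the two limits leave unreadable from compound 1 to compound 2), and it has no readable size, so it gives no direction for the new change. With compound 1 and compound 2 both resting at the limit of > 80000 nM in this assay, at which 2 of the 3 values shown sit, despite their different groups on the sulfur, no clear gain or loss is expected in this assay, and compound 4 is expected to stay close to that limit. The estimated step of an at least 1.3-fold lower number from compound 2 to compound 4 (0.12 log units; that floor lies within the scatter) is expected to be too small to read with any confidence. The estimated value for compound 4 is 60000 nM with a range from 15000 nM to 120000 nM and a report of a limit alone is the likeliest outcome.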

Compound 4, half-maximal inhibitory concentration: 9840 nM
Beside the measured number, compound 4's estimate is 6.1-fold (0.79 log units) above it, and the stated range ends above it.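

In this assay, the group on the sulfur proves able to bring the reading off the limit, as 1,3,4-thiadiazol-2-yl in place of 6-methoxy-1,3-benzothiazol-2-yl gives an at least 8.1-fold lower number from compound 2 to compound 4 (0.91 log units; beyond the scatter). As far as these compounds go, the comparison with the other limit gives an at least 8.1-fold lower number from compound 1 to compound 4 (0.91 log units; beyond the scatter), and both sizes are floors only, so the true gaps remain unknown. Of the compounds that differ only in the group on the sulfur, compound 4 alone has a true number, and the other two rest at a limit: the limit of > 80000 nM in this assay, at which 2 of the 4 values shown sit.

The size of the group alone does not settle the matter, since the group of 6 heavy atoms on the sulfur of compound 1 still leaves that compound at a limit, so these compounds cannot separate the effect of group size from that of the ring itself. From the compounds shown here alone, it remains open whether an amine or a methyl group on the 1,3,4-thiadiazol-2-yl ring, or a 1,3,4-oxadiazol-2-yl group in its place, would keep, improve or lose the reading of compound 4.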